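Enlarging the ring on the sulfonyl sulfur of compound 1

A few compounds are considered here, and "the series" means these few. Any claim that something is new, unique, unknown or untested is made for them only; others in the source may bear on it.

Compound 1 `CN1CCN(S(=O)(=O)c2ccc(-c3ccc4nncc(Nc5ccc(OCc6cccc(F)c6)c(Cl)c5)c4c3)cc2)CC1`: > 15 uM
Compound 2 `O=S(=O)(c1ccc(-c2ccc3c(Nc4ccc(OCc5ccccc5)c(Cl)c4)nccc3c2)cc1)N1CCOCC1`: > 5 uM
Compound 3 `CN1CCN(S(=O)(=O)c2ccc(-c3ccc4cnnc(Nc5ccc(OCc6cccc(F)c6)c(Cl)c5)c4c3)cc2)CC1`: > 5 uM

In a toxicity assay on HepG2 cells (Homo sapiens) for cytotoxicity, read by MTT assay, with a stated time of 48 h (on this read-out lower numbers stand for higher toxicity in this test and higher numbers for lower toxicity in this test), compound 1 gives > 15 uM, which is a limit and not a number. The values of compound 2 and compound 3 are limits too, so no exact number is available yet. Compound 4 `CN1CCCN(S(=O)(=O)c2ccc(-c3ccc4nncc(Nc5ccc(OCc6cccc(F)c6)c(Cl)c5)c4c3)cc2)CC1` differs from compound 1 in one place, with 4-methyl-1,4-diazepan-1-yl in place of 4-methylpiperazin-1-yl on a sulfonyl sulfur. For the measured compounds named here, no measured pair of compounds shows this kind of change. A step no larger than the usual scatter, in neither particular direction, is therefore expected in this assay. The expected change is a number no higher from compound 1 to compound 4 (the limit leaves the size open). For compound 4 the estimated value is 15 uM, within an expected range from 6 uM to 40 uM.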

Compound 4, half-maximal toxic concentration: 7.3 uM
The estimate for compound 4 lay 2.1-fold (0.31 log units) above the measured number; the measured number falls inside the stated range.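

For the compounds shown here, compound 4 gives the first exact number in this assay. Enlarging the ring on the sulfonyl sulfur gives an at least 2.0-fold lower number from compound 1 to compound 4 (0.31 log units; beyond the scatter), so the toxicity read-out responds to a change at this position. The full size of the step stays unknown because it starts from a limit: the limit of > 15 uM in this assay, at which 1 of the 4 values shown sits.

A single pair cannot separate the effect of the seven-membered ring from that of the extra carbon. The compounds shown also leave open how an open-chain dimethylamino group or a group carrying a carboxylic acid would read on this sulfur.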